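Series notes: chloro for methoxy, Vero cytotoxicity read-out

The source may hold more compounds than are shown below. What is called first, only, known or untested is meant among the compounds shown, and "the series" means these compounds.

Measured compounds:
compound 1 `O=C1CSC(c2ccc(Cl)cc2)N1CCN1CCCCC1`: 13%
compound 2 `COc1cccc(C2SCC(=O)N2CCN2CCCCC2)c1`: 11%

Both compounds share the same core and were run in an ADME assay on Vero cells (Chlorocebus sabaeus) for cytotoxicity, read by neutral red uptake, tested at 1575 ug/mL; on this read-out higher numbers stand for a weaker effect at the one concentration tested and lower numbers for a stronger effect. In this assay compound 1 gives 13%. Compound 2 gives 11%, a number that sits alongside that of compound 1 and inside the usual scatter of repeated measurements, so the two readings are not distinguishable from each other; both describe a strong effect at the one concentration tested.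

Compound 3 `O=C1CSC(c2cccc(Cl)c2)N1CCN1CCCCC1` is the next member of the series. It differs from compound 2 in one place: chloro in place of methoxy on an aromatic carbon. Among the measured compounds shown here, no step between two measured compounds is available in this assay, so nothing in the data shows how a change on this ring moves the reading. For the measured compounds named here, the only comparison at hand, compound 1 against compound 2, shows two values that agree with each other. On that basis the step from compound 2 to compound 3 is expected to be small, a number 1 percentage points higher from compound 2 to compound 3 (within the scatter), in no particular direction and not beyond the scatter. Compound 3 is therefore estimated at 12%, with a range from 4% to 24%.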

Compound 3, a percentage reported as activity, at one concentration (the size of the read-out at that concentration, not a potency): 20%
For compound 3 the middle estimate is 8 percentage points below the measured one, within the range that was stated.
By their numbers in this assay, from the lowest: compounds 2, 1 and 3 (each within the scatter of the next).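

In this assay, among the compounds shown here, chloro in place of methoxy on an aromatic carbon of the six-membered aromatic ring, meta to a large group, gives a number 9 percentage points higher from compound 2 to compound 3 (within the scatter) and provides the first step that can be read at this place. Replacing 4-chlorophenyl with 3-chlorophenyl on a saturated ring carbon gives a number 7 percentage points higher from compound 1 to compound 3 (within the scatter) and adds a second readable step, so neither the exchange of methoxy for chloro nor this change of chlorophenyl group separates the compounds on this read-out. No available measurement bears on what lies behind either step.

The compounds shown leave open whether any other group on this aromatic carbon, such as an amine or a carboxylic acid, would give a step beyond the scatter from compound 3 in this assay on this shared core. They also leave open how a plain hydrogen or a longer chain at the same place would read, and so whether this position can move the reading at all.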